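A benzyl swap at the limit of the assay

This account rests on a few compounds, and the source may have more. Where it says the series, first, only, none or still open, it means among the compounds named here.

Measured in a functional assay on MCF7 cells (Homo sapiens) for inhibition, read by sulforhodamine B assay; a higher number here means a weaker inhibitor, a lower number a stronger inhibitor:
compound 1 `O=C1C(N2CCC2)=CC(=O)c2c1nc1n2[C@H]2OC[C@@H](O)[C@H]2OC1`: > 16000 nM
compound 2 `O=C1C(NC2CC2)=CC(=O)c2c1nc1n2[C@H]2OC[C@@H](O)[C@H]2OC1`: > 16000 nM

Compound 2 stands only at a limit of this assay, > 16000 nM, and not at a number. Compound 1 likewise reaches only a limit, > 16000 nM. All the evidence therefore comes down to the limit of > 16000 nM in this assay, at which 2 of the 2 values shown sit.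

The next compound, compound 3 `O=C1C(NCc2ccccc2)=CC(=O)c2c1nc1n2[C@H]2OC[C@@H](O)[C@H]2OC1`, carries benzyl in place of cyclopropyl on an amine nitrogen. For the measured compounds named here, only one measured step bears on this change, a step that the two limits leave unreadable from compound 1 to compound 2, and it gives no size to carry over. Going by the values given here, no large step is therefore expected, only a possible slight move towards the stronger side. The expected step, an at least 1.1-fold lower number from compound 2 to compound 3 (0.05 log units; that floor lies within the scatter), is measured from a limit and is correspondingly uncertain. The estimate for compound 3 is 14000 nM, with an expected range from 4000 nM to 32000 nM.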

Compound 3, half-maximal inhibitory concentration: > 8000 nM
Compound 3 was reported as a limit (the forecaster's own chance of this, stated with the estimate: 60%); the middle value lies beyond the limit too.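

In this assay compound 3 gives only a limit, > 8000 nM. Compound 1 and compound 2 also stand at limits, so the steps from either of them to compound 3 cannot be read. The compounds shown leave open whether azetidin-1-yl, cyclopropylamino and benzylamino differ at all in this assay.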